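This account rests on a few compounds, and the source may have more. Where it says the series, first, only, none or still open, it means among the compounds named here.

Measured so far in an assay on isolated protein for inhibition of histone-lysine N-methyltransferase EZH2 (Homo sapiens), with a stated time of 1 h, in the presence of a further agent that is not named here; a lower number here means a stronger inhibitor, a higher number a weaker inhibitor:
Compound 1 `Cc1cc(C)c(CNC(=O)c2cc(C#N)cc3c2CCN3C2CCOCC2)c(=O)[nH]1` gives 15700 nM.
Compound 2 `Cc1cc(C)c(CNC(=O)c2cc(C#N)cc3c2C(C)CN3C(C)C)c(=O)[nH]1` gives > 100000 nM; 88 nM (2 entries) across its two entries.
Compound 3 `Cc1cc(C)c(CNC(=O)c2cc(C#N)cc3c2CCN3C2CCCC2)c(=O)[nH]1` gives 571 nM.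

Compound 3 stands lowest of the two single numbers, with compound 1 nearest; the step of a 27-fold lower number from compound 1 to compound 3 (1.44 log units; beyond the scatter) shows how far apart they lie. Compound 4 `Cc1cc(C)c(CNC(=O)c2cc(C#N)cc3c2CCN3C(C)C)c(=O)[nH]1` differs from compound 3 in one place: isopropyl in place of cyclopentyl on a nitrogen on an aromatic ring in a ring. For the measured compounds named here, no measured step swaps exactly these two groups, so the guides are a 27-fold lower number from compound 1 to compound 3 (1.44 log units; beyond the scatter), which shows that the group on this nitrogen can shift the number strongly, and the scattered entries of compound 2 (the several entries of compound 2 in this assay, > 100000 nM; 88 nM (2 entries)), which carries the same isopropyl together with a further methyl. Compound 4 is therefore expected to stay in the region of compound 3 or somewhat lower, the step of a 1.9-fold lower number from compound 3 to compound 4 (0.28 log units; within the scatter) being the expectation. Compound 4 is estimated at 300 nM, with a range from 60 nM to 1500 nM.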

Compound 4, half-maximal inhibitory concentration: 26800 nM
Compound 4: middle estimate off by 89-fold (1.95 log units), on the low side, and the stated range ends below it.
By their numbers in this assay, from the lowest: compound 3; then compounds 1 and 4 (each within the scatter of the next).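

Replacing cyclopentyl with isopropyl on this nitrogen gives a 47-fold higher number from compound 3 to compound 4 (1.67 log units; beyond the scatter), so a group of carbon only, with no hydrogen-bond donors or acceptors, can also leave the number high. Against oxan-4-yl, isopropyl gives a 1.7-fold higher number from compound 1 to compound 4 (0.23 log units; within the scatter), which leaves cyclopentyl alone among these three groups with the low number.

As far as these compounds go, compound 2 gives no firm reading of its added methyl, because its two entries disagree and one is a limit of the assay: the several entries of compound 2 in this assay, > 100000 nM; 88 nM (2 entries) Whether a cyclobutyl or cyclohexyl ring on this nitrogen would keep the low number of compound 3 stays open.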